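The source may report more compounds than this note shows. Statements on the series, on what has been measured and on what is new or still open speak of the compounds shown alone.

Within the data shown here, compound 1 `Cc1ccc(N2C(=O)C/C(=C\c3cccc(C(=O)Nc4cccc(F)c4)c3)C2=O)cc1` is the one compound here with a definite number in an ADME assay on SW480 cells (Homo sapiens) for cytotoxicity, read by MTT assay, with a stated time of 72 h (a higher number here means a weaker inhibitor, a lower number a stronger inhibitor), where compound 1 gives 96900 nM. Compound 2 `O=C(Nc1cccc(F)c1)c1cccc(/C=C2\CC(=O)N(c3ccccc3)C2=O)c1` reaches only the limit of the assay, since in this assay compound 2 gives > 100000 nM, which is a limit and not a number (the limit of > 100000 nM in this assay, at which 1 of the 2 values shown sits). Among the measured compounds shown here, the single measured step, an at least 1.0-fold higher number from compound 1 to compound 2 (0.01 log units; that floor lies within the scatter), stays within the scatter and shows no change that can be read. Compound 3 `CCc1cccc(NC(=O)c2cccc(/C=C3\CC(=O)N(c4ccc(C)cc4)C3=O)c2)c1` differs from compound 1 by ethyl in place of fluoro on an aromatic carbon. For the measured compounds named here, no measured step covers an exchange of this kind, so nothing here argues for movement in either direction. A step beyond the scatter is therefore not expected in this assay. The step expected from this exchange is a 1.0-fold higher number from compound 1 to compound 3 (0.01 log units; within the scatter). Compound 3 is expected to give near 100000 nM, within 40000 nM to 250000 nM, and may well reach only the limit.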

Compound 3, half-maximal inhibitory concentration: 65300 nM
The estimate for compound 3 lay 1.5-fold (0.19 log units) above the measured number, within the range that was stated.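

Ethyl in place of fluoro on this aromatic carbon gives a 1.5-fold lower number from compound 1 to compound 3 (0.17 log units; within the scatter) in this assay, so the two carbons of ethyl are accepted here in place of the single fluorine without a change that can be read. Among these compounds, this is the first measured step at this position, since the only earlier step concerned the methyl group of compound 1, elsewhere in the molecule. Like compound 1, compound 3 gives a definite number and does not sit at the limit of the assay: the limit of > 100000 nM in this assay, at which 1 of the 3 values shown sits.

With only fluoro and ethyl shown in this place, it remains open whether an amine, a carboxylic acid or a longer chain would move the number beyond the scatter. From the compounds shown here alone, it also remains open whether such a group would do so on the shared core of compound 1 alone or with the methyl group exchanged as well.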